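Picolinoyl for Acetyl on a Piperidine Amide

The compounds below may be only part of what the source reports. "The series", "measured", "known", "first", "only" and "open" are said of these compounds alone.

The series shares one core, seen in compound 3 `CC(=O)N1CCC(C(=O)N2N=CCC2c2ccccc2)CC1`, whose value in a physicochemical assay for lipophilicity, read by HPLC, measured as chromatographic lipophilicity, at pH 7.4 (a higher number here means a more lipophilic compound, a lower number a more polar compound), is 2.5, the lowest of the three measured. Compound 2 `CCC(=O)N1CCC(C(=O)N2N=CCC2c2ccccc2)CC1` gives 3.2 and compound 1 `O=C(C1CCN(C(=O)C(F)(F)F)CC1)N1N=CCC1c1ccccc1` gives 4.9. Compound 4 `O=C(c1ccccn1)N1CCC(C(=O)N2N=CCC2c2ccccc2)CC1` is unmeasured; it differs from compound 3 by pyridin-2-yl in place of methyl on a carbonyl carbon. The nearest measured steps are a number 0.70 log units lower from compound 2 to compound 3 (beyond the scatter) and a number 2.40 log units lower from compound 1 to compound 3 (beyond the scatter), both at the same carbonyl carbon, though neither brings in a ring. An increase beyond the scatter is therefore expected, of the size a number 1.30 log units higher from compound 3 to compound 4 (beyond the scatter). Compound 4 is estimated at 3.8, between 3.2 and 4.5.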

Compound 4, distribution coefficient: 3.1
Beside the measured number, compound 4's estimate is 0.70 log units above it, and the stated range ends above it.
By their numbers in this assay, from the lowest: compound 3; then compounds 4 and 2 (each within the scatter of the next); then compound 1.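

At this carbonyl carbon, pyridin-2-yl in place of methyl puts an aromatic ring here for the only time in the series, and this assay gives a number 0.60 log units higher from compound 3 to compound 4 (beyond the scatter). Against ethyl the same ring gives a number 0.10 log units lower from compound 2 to compound 4 (within the scatter), while against trifluoromethyl it gives a number 1.80 log units lower from compound 1 to compound 4 (beyond the scatter), so this larger group reads level with ethyl and far from trifluoromethyl. Nothing available explains this result. Left open is how phenyl, pyridin-3-yl or pyridin-4-yl would read at this carbonyl carbon, so the share of the ring nitrogen in these steps remains unknown.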